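From Butylamino to Methylsulfanyl: Expected Shift in Spleen Activation

A few compounds are considered here, and "the series" means these few. Any claim that something is new, unique, unknown or untested is made for them only; others in the source may bear on it.

Measured compounds:
compound 1, `CCCCNc1nc(N)c2nc(O)n(Cc3ccccc3)c2n1`, 1 uM
compound 2, `COc1ccc(Cn2c(O)nc3c(N)ncnc32)cc1`, 10 uM

Both compounds were tested in a functional assay (spleen, spleen) for activation, with Mus musculus as the target; a higher number here means that more compound is needed for the effect, a lower number that less compound is needed. Compound 1 gives 1 uM, the lowest of the two numbers, while compound 2 gives 10 uM, a higher number whose gap to compound 1 lies beyond the scatter. Compound 2 differs from compound 1 in more than one place, so the two values alone do not isolate any single change.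

Compound 3, `CSc1nc(N)c2nc(O)n(Cc3ccccc3)c2n1`, has not yet been measured. It differs from compound 1 in one place: methylsulfanyl in place of butylamino on an aromatic carbon. For the measured compounds named here, no measured pair shows this exact change, so there is no direct precedent for the size of the step. A modest move toward a higher number is expected, a 2.0-fold higher number from compound 1 to compound 3 (0.30 log units; within the scatter), which may still fall within the scatter. Compound 3 is therefore estimated at 2 uM, with a range from 0.5 uM to 10 uM.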

Compound 3, minimum effective concentration: 0.1 uM
Beside the measured number, compound 3's estimate is 20-fold (1.30 log units) above it, and the stated range ends above it.
By their numbers in this assay, from the lowest: compound 3; then compound 1; then compound 2.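

At this position, on an aromatic carbon between two ring nitrogen atoms, butylamino is not required for the effect in this assay, since methylsulfanyl in its place gives a 10-fold lower number from compound 1 to compound 3 (1.00 log units; beyond the scatter) and this step lies beyond the usual scatter. The incoming group has fewer heavy atoms and no hydrogen-bond donor, so in this pair neither the longer chain nor that donor is needed to reach the lower number. Nothing available explains why the number falls.

This single change swaps the linking atom and shortens the chain together, so the pair cannot show which of the two matters. A methylamino group, with the nitrogen kept and the chain short, or a butylsulfanyl group, with the sulfur kept and the chain long, would separate them.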